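The source may hold more compounds than are shown below. What is called first, only, known or untested is meant among the compounds shown, and "the series" means these compounds.

Of the compounds shown here, three have so far been measured in an assay on mitochondria for inhibition of Amine oxidase [flavin-containing] B (Bos taurus); on this read-out lower numbers stand for stronger inhibition and higher numbers for weaker inhibition. Compound 1 `Cc1csc(N/N=C/c2ccc(Cl)cc2Cl)n1` gives 17 nM. Compound 2 `Clc1ccc(/C=N/Nc2nc(-c3ccccc3)cs2)c(Cl)c1` differs from it by phenyl in place of methyl on an aromatic carbon, and in this assay compound 2 gives 132 nM, a step of a 7.8-fold higher number from compound 1 to compound 2 (0.89 log units; beyond the scatter). Compound 3 `Cc1csc(/N=C/c2ccccc2C)n1` gives 331 nM in this assay. The difference between the core of compound 1 and the core of compound 3 is not broken down here.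

Compound 4 `Cc1ccccc1/C=N/c1nc(-c2ccccc2)cs1` has not yet been measured. It differs from compound 3 by phenyl in place of methyl on an aromatic carbon. This is the same kind of change as from compound 1 to compound 2, though around the place the ring atom here bears a group of 9 heavy atoms rather than a large group. Because the earlier step was a 7.8-fold higher number from compound 1 to compound 2 (0.89 log units; beyond the scatter), the expected step is a 6.6-fold higher number from compound 3 to compound 4 (0.82 log units; beyond the scatter), with some added uncertainty since the cores differ. Compound 4 is therefore estimated at 2200 nM, expected to fall between 600 nM and 8000 nM.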

Compound 4, inhibition constant: 501 nM
Estimate against measurement, compound 4: 4.4-fold (0.64 log units) above; measured number outside the range, below it.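

In this assay, phenyl in place of methyl on the ring next to the ring nitrogen gives a 1.5-fold higher number from compound 3 to compound 4 (0.18 log units; within the scatter) and so leaves no clear change on this core. The same swap therefore does not carry over at the same size from one core to the other: the same change on two cores in this assay, a 7.8-fold higher number (0.89 log units; beyond the scatter) from compound 1 to compound 2 and a 1.5-fold higher number (0.18 log units; within the scatter) from compound 3 to compound 4, 5.1-fold (0.71 log units) apart, beyond the scatter of two such steps. This shows that the step cannot simply be transferred between these two cores, but two pairs do not show which difference between the cores matters.

Still open, from the compounds shown here alone, is how an amine or a carboxylic acid would compare with methyl and phenyl at this place. Also open, going by these compounds, is whether a further core would show the larger step, the smaller one, or neither.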